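Cytotoxicity limits across three amides and a pyrimidinyl analogue

A few compounds are considered here, and "the series" means these few. Any claim that something is new, unique, unknown or untested is made for them only; others in the source may bear on it.

The shared core carries an amide whose nitrogen bears a varying aryl group. Compound 1 `CC(C)n1ncc2c(C(=O)Nc3cccc(F)c3)cc(-c3cccs3)nc21` carries 3-fluorophenyl there. In an ADME assay on LLC-MK2 cells (Macaca mulatta) for cytotoxicity, read by spectrophotometry and crystal violet staining, with a stated time of 4 days (a lower number here means that less compound is tolerated, a higher number that more compound is tolerated), compound 1 gives > 200000 nM, which is a limit of the assay rather than a number. Compound 2 `CC(C)n1ncc2c(C(=O)Nc3cccnc3)cc(-c3cccs3)nc21` carries pyridin-3-yl; in this assay compound 2 gives > 200000 nM, again a limit. Compound 3 `CC(C)n1ncc2c(C(=O)Nc3ccc(F)c(F)c3)cc(-c3cccs3)nc21` carries 3,4-difluorophenyl; in this assay compound 3 gives > 200000 nM, also a limit. Compound 3 therefore stands at the same limit as the other two, and the steps a step that the two limits leave unreadable from compound 1 to compound 2, a step that the two limits leave unreadable from compound 1 to compound 3 and a step that the two limits leave unreadable from compound 2 to compound 3 cannot be read, because of the limit of > 200000 nM in this assay, at which 3 of the 3 values shown sit.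

Compound 4 `CC(C)n1ncc2c(C(=O)Nc3ccncn3)cc(-c3cccs3)nc21` differs from compound 3 in one place: pyrimidin-4-yl in place of 3,4-difluorophenyl on an amide-type nitrogen. Of the three measured steps, a step that the two limits leave unreadable from compound 2 to compound 3 comes closest to this change, and it too gives no size. With every value sitting at the limit, no step beyond the scatter is expected in this assay, and the expected step of a number no higher from compound 3 to compound 4 (the limit leaves the size open) is nil. For compound 4 the expected value in this assay is 200000 nM, within a range from 100000 nM to 400000 nM, most probably reported once more only as a limit.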

Compound 4, half-maximal cytotoxic concentration: 50000 nM
Beside the measured number, compound 4's estimate is 4.0-fold (0.60 log units) above it, and the stated range ends above it.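

At the amide-type nitrogen, pyrimidin-4-yl gives an at least 4.0-fold lower number from compound 3 to compound 4 (0.60 log units; beyond the scatter) as well as an at least 4.0-fold lower number from compound 2 to compound 4 (0.60 log units; beyond the scatter) and an at least 4.0-fold lower number from compound 1 to compound 4 (0.60 log units; beyond the scatter) in this assay and so shows that this position can take the reading off the limit. Compound 2, with pyridin-3-yl, also carries a ring hetero atom yet gives > 200000 nM and this value is a limit, so compound 2 goes against tying the lower number to any ring hetero atom. On these data alone, the true size of all three steps stays open, and each is only a lower bound: the limit of > 200000 nM in this assay, at which 3 of the 4 values shown sit.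

The compounds shown leave open whether the lower number belongs to pyrimidin-4-yl alone or extends to other rings. A pyrazin-2-yl group or a morpholine ring on this nitrogen could separate these readings.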